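Swapping the amide-bound aryl group on a p300 inhibitor

A few compounds are considered here, and "the series" means these few. Any claim that something is new, unique, unknown or untested is made for them only; others in the source may bear on it.

Of the compounds shown here, three have been measured in an assay on isolated protein for inhibition of histone acetyltransferase p300 (Homo sapiens), with a stated time of 60 min; on this read-out higher numbers stand for weaker inhibition and lower numbers for stronger inhibition. Compound 1 `COc1ccc(NC(=O)[C@H]2CCCN2C(=O)C(C)(C)c2ccc(Cl)cc2)cc1` gives 50.1 nM. Compound 2 `COc1ccc(NC(=O)[C@H]2CCCN2C(=O)C2(c3cccc(Cl)c3)CCCC2)nc1` gives 2 nM. Compound 3 `COc1ccc(NC(=O)[C@H]2CCCN2C(=O)C2(c3ccccc3)CCCC2)cc1` gives 79.4 nM. Among these three numbers compound 2 stands lowest, and its gaps to compound 1 and to compound 3 both lie beyond the usual scatter of repeated measurements, so compound 2 is the strongest inhibitor of the three on this read-out.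

Compound 4 `O=C(Nc1ccc2[nH]ccc2n1)[C@H]1CCCN1C(=O)C1(c2cccc(Cl)c2)CCCC1` has not yet been measured. It differs from compound 2 in one place: a group of 9 heavy atoms (7 carbon, 2 nitrogen; one five-membered aromatic ring with 1 hetero atom, one six-membered aromatic ring with 1 hetero atom) in place of a group of 8 heavy atoms (6 carbon, 1 nitrogen, 1 oxygen; one six-membered aromatic ring with 1 hetero atom), on an amide-type nitrogen. Everything else in the shared core is kept.

Within the data shown here, no measured pair shows what this kind of swap does here, so the expectation rests on compound 2 alone, with its value of 2 nM as the starting point. The step from compound 2 to compound 4 is expected to be small, upward if anything, and roughly at the edge of the scatter, a 2.5-fold higher number from compound 2 to compound 4 (0.40 log units; beyond the scatter). Compound 4 is therefore estimated at 5 nM in this assay, within a range from 1 nM to 25 nM.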

Compound 4, half-maximal inhibitory concentration: 0.159 nM
Compound 4: the middle estimate sits 31-fold (1.50 log units) above what was measured; the measured number lies below the stated range.
By their numbers in this assay, from the lowest: compound 4; then compound 2; then compounds 1 and 3 (each within the scatter of the next).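

In this assay, the group on the amide-type nitrogen proves to be a strong lever: exchanging 5-methoxypyridin-2-yl for the group with one five-membered and one six-membered aromatic ring gives a 13-fold lower number from compound 2 to compound 4 (1.10 log units; beyond the scatter), a large step. Among these compounds, the earlier compounds differ in more than one place, so this is the first change at this position that can be read alone. The entering group has 1 hydrogen-bond donor and 1 hydrogen-bond acceptor, against 0 and 2 in the group it replaces, but this single step cannot show whether those counts matter.

Still open, as far as these compounds go, is how other groups at this position would behave, such as a pyridin-2-yl carrying an amine or a carboxylic acid in place of the methoxy. No measurement here bears on why the number falls.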